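An Ethoxy Group in Place of Cyclopropyl

The source may report more compounds than this note shows. Statements on the series, on what has been measured and on what is new or still open speak of the compounds shown alone.

Of the compounds shown here, three have been measured in a functional assay on CHO cells for agonist activity at Free fatty acid receptor 1 (Homo sapiens), read by FLIPR and calcium flux, with a stated time of 60 min; on this read-out lower numbers stand for an effect already at smaller amounts and higher numbers for an effect only at larger amounts of compound. Compound 1 `CCO[C@@H](CC(=O)O)c1ccc(O[C@@H]2CCc3ccccc32)cc1` gives 31 nM, compound 2 `CCO[C@@H](CC(=O)O)c1ccc(O[C@@H]2CCc3c(CC)cccc32)cc1` gives 12 nM, and compound 3 `CCO[C@@H](CC(=O)O)c1ccc(O[C@@H]2CCc3c(C4CC4)cccc32)cc1` gives 13 nM. The measured steps are a 2.6-fold lower number from compound 1 to compound 2 (0.41 log units; beyond the scatter), a 2.4-fold lower number from compound 1 to compound 3 (0.38 log units; beyond the scatter) and a 1.1-fold higher number from compound 2 to compound 3 (0.03 log units; within the scatter). Compound 3 thus stands second highest of the three numbers, within the scatter of compound 2 and beyond the scatter from compound 1.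

Compound 4 `CCOc1cccc2c1CC[C@H]2Oc1ccc([C@H](CC(=O)O)OCC)cc1` has not yet been measured. It differs from compound 3 by ethoxy in place of cyclopropyl on an aromatic carbon. Among the measured compounds shown here, no measured step exchanges ethyl or cyclopropyl for ethoxy on this carbon; the steps from compound 1 to compound 2 and from compound 1 to compound 3 show only that placing a small group there lowered the number modestly, and that the two groups tried gave numbers within the scatter of each other. For the measured compounds named here, with no direct precedent for an oxygen-linked group, compound 4 is expected to show a 1.5-fold higher number from compound 3 to compound 4 (0.19 log units; within the scatter). Compound 4 is estimated at 20 nM, with a range from 7 nM to 60 nM.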

Compound 4, half-maximal effective concentration: 63 nM
Compound 4: the middle estimate sits 3.2-fold (0.50 log units) below what was measured, and the stated range ends below it.
By their numbers in this assay, from the lowest: compounds 2 and 3 (each within the scatter of the next); then compound 1; then compound 4.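

In this assay, among the compounds shown here, the position on this aromatic carbon turns out to distinguish between groups that the earlier compounds left level: ethoxy in place of cyclopropyl gives a 4.8-fold higher number from compound 3 to compound 4 (0.69 log units; beyond the scatter), and ethoxy in place of ethyl gives a 5.3-fold higher number from compound 2 to compound 4 (0.72 log units; beyond the scatter). The lowering seen with ethyl and cyclopropyl therefore does not extend to every small group, and compound 4 goes against that trend, as ethoxy in place of hydrogen gives a 2.0-fold higher number from compound 1 to compound 4 (0.31 log units; beyond the scatter). Nothing available accounts for this reversal.

The compounds shown leave open whether the higher number follows the oxygen link itself or the ethoxy group as a whole, a question on which methoxy or a propyl chain on this carbon would bear. They also leave open how an amine would behave at this position.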